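The compounds below may be only part of what the source reports. "The series", "measured", "known", "first", "only" and "open" are said of these compounds alone.

Of the compounds shown here, three built on a shared core have been measured, and a fourth is waiting. Compound 1 `CC(C)COc1cccc(C(=O)Nc2cccc(C(=O)O)c2)c1` carries an isobutoxy chain on one aromatic ring. In an assay on isolated protein for agonist activity at Bile acid receptor (Homo sapiens), read by TR-FRET, with a stated time of 3 h, in the absence of a further agent (on this read-out lower numbers stand for an effect already at smaller amounts and higher numbers for an effect only at larger amounts of compound), compound 1 gives 1130 nM. Compound 3 `CC(C)CCOc1cccc(C(=O)Nc2cccc(C(=O)O)c2)c1` differs from compound 1 by isobutyl in place of isopropyl on a saturated chain carbon bound to an oxygen on an aromatic ring. Compound 3 gives 2760 nM; this change made a 2.4-fold higher number from compound 1 to compound 3 (0.39 log units; beyond the scatter). Compound 2 `CC(C)COc1ccc(C(=O)Nc2cccc(C(=O)O)c2)cc1` has the same atoms as compound 1 joined differently; the difference between the two cores is not broken down here. Compound 2 gives 357 nM, the lowest of the three numbers, with compound 1 the nearest to it and compound 3 the furthest.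

Compound 4 `CC(C)CCOc1ccc(C(=O)Nc2cccc(C(=O)O)c2)cc1` stands to compound 2 as compound 3 stands to compound 1: isobutyl in place of isopropyl on a saturated chain carbon bound to an oxygen on an aromatic ring. The place of the change is described in the same words for both pairs, so it is the same change made on the other core. Within the data shown here, only one measured instance of this change exists, so the expectation rests on a single step.

Among the measured compounds shown here, the number for compound 4 is expected to rise by about as much as from compound 1 to compound 3, because a 2.4-fold higher number from compound 1 to compound 3 (0.39 log units; beyond the scatter) is the only guide available, giving an estimated 2.4-fold higher number from compound 2 to compound 4 (0.38 log units; beyond the scatter). For compound 4 the estimate is therefore 860 nM, expected to fall between 400 nM and 2000 nM.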

Compound 4, half-maximal effective concentration: 215 nM
Estimate against measurement, compound 4: 4.0-fold (0.60 log units) above; the measured number lies below the stated range.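

On the core of compound 2, putting isobutyl in place of isopropyl gives a 1.7-fold lower number from compound 2 to compound 4 (0.22 log units; within the scatter) in this assay, so compound 2 and compound 4 cannot be told apart on this read-out, whereas the same change on the core of compound 1 gave a step beyond the scatter. The effect of this change therefore did not carry from one core to the other, and the gap between the two steps is larger than repeated measurements alone would be expected to produce: the same change on two cores in this assay, a 2.4-fold higher number (0.39 log units; beyond the scatter) from compound 1 to compound 3 and a 1.7-fold lower number (0.22 log units; within the scatter) from compound 2 to compound 4, 4.1-fold (0.61 log units) apart, beyond the scatter of two such steps. Among these compounds, this shows that a step measured on one core was a poor guide to the other here, but it rests on only two pairs of compounds, so it gives no general rule for this series and does not explain why the two cores respond differently.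

The compounds shown leave open how either core would respond to a longer chain such as hexyloxy, or to a chain ending in a ring such as benzyloxy. They also leave open whether the two cores would again part ways if an amine or a tetrazole took the place of the carboxylic acid.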